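The compounds below may be only part of what the source reports. "The series", "measured", "known", "first", "only" and "open" are said of these compounds alone.

Working notes on the series. Two cores are in play, built from the same atoms joined differently; the difference between the two cores is not broken down here. Compound 1 `Cc1ccc(C(=O)NNC(=O)c2ccc(NS(=O)(=O)c3cnc(O)nc3O)cc2)cc1` and compound 3 `Cc1ccc(C(=O)NNC(=O)c2cccc(NS(=O)(=O)c3cnc(O)nc3O)c2)cc1` each carry a 4-methylphenyl on a carbonyl carbon, while compound 2 `O=C(NNC(=O)c1ccccc1Cl)c1ccc(NS(=O)(=O)c2cnc(O)nc2O)cc1` and compound 4 `O=C(NNC(=O)c1ccccc1Cl)c1cccc(NS(=O)(=O)c2cnc(O)nc2O)c1` carry a 2-chlorophenyl in that place.

In a functional assay on OVCAR-3 cells (Homo sapiens) for antiproliferative activity, read by MTT assay, with a stated time of 24 h (on this read-out higher numbers stand for weaker inhibition and lower numbers for stronger inhibition), compound 1 returns only a limit, > 20000 nM. Compound 3 also returns only a limit in this assay, > 20000 nM. Going by the values given here, compound 2 is the one member with a number in this assay, giving 5220 nM.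

The change from compound 1 to compound 2 is 2-chlorophenyl in place of 4-methylphenyl on a carbonyl carbon. It gave an at least 3.8-fold lower number from compound 1 to compound 2 (0.58 log units; beyond the scatter); the true size of that step is known only as a lower bound because of the limit of > 20000 nM in this assay, at which 2 of the 3 values shown sit. The change from compound 3 to compound 4 is 2-chlorophenyl in place of 4-methylphenyl on a carbonyl carbon. The surroundings of the place read the same word for word on both cores, so this is the same change carried over to the core of compound 3.

Among the compounds with values here, what to expect for compound 4 in this assay rests on the single measured step of an at least 3.8-fold lower number from compound 1 to compound 2 (0.58 log units; beyond the scatter) on the other core. A step of similar size is expected, an at least 2.2-fold lower number from compound 3 to compound 4 (0.34 log units; beyond the scatter), though with compound 3 sitting at the limit > 20000 nM the outcome may again be a limit. Compound 4 is expected near 9000 nM, within 3000 nM to 40000 nM.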

Compound 4, half-maximal inhibitory concentration: 7300 nM
For compound 4 the middle estimate is 1.2-fold (0.09 log units) above the measured one, within the range that was stated.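

In this assay, the change to 2-chlorophenyl in place of 4-methylphenyl on a carbonyl carbon carries over to the second core in the same direction, giving an at least 2.7-fold lower number from compound 3 to compound 4 (0.43 log units; beyond the scatter). Set side by side, the two steps show a lower number on both cores, which is as far as the transfer can be followed in this series: the same change on two cores in this assay, an at least 3.8-fold lower number (0.58 log units; beyond the scatter) from compound 1 to compound 2 and an at least 2.7-fold lower number (0.43 log units; beyond the scatter) from compound 3 to compound 4; the limit leaves it open whether they differ. From the compounds shown here alone, what this does not show is whether the change is worth the same amount on each core, since both steps are known only as lower bounds and the true starting points remain unknown, because of the limit: the limit of > 20000 nM in this assay, at which 2 of the 4 values shown sit.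

The change removes a methyl and brings in a chlorine at once, so the compounds shown do not separate what each of these contributes, and a plain phenyl in the same place on a carbonyl carbon would be needed to tell them apart. Also open, going by these compounds, is whether the trend holds for anything else at this place, such as an amine, a carboxylic acid or a longer chain, on either core.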